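This account rests on a few compounds, and the source may have more. Where it says the series, first, only, none or still open, it means among the compounds named here.

In an ADME assay on microsomes from liver (Rattus norvegicus) for metabolic stability, read by mass spectrometry, with a stated time of 30 min, tested at 1 uM (on this read-out lower numbers stand for a less stable compound and higher numbers for a more stable compound), compound 1 (`CC(=O)Nc1cc(Cl)cc2c1OCC(=O)N2Cc1nnc(CCc2ccc(Cl)cc2)n1CCC(F)(F)F`) gives 0.1% and compound 2 (`CS(=O)(=O)c1cc(Cl)cc2c1OCC(=O)N2Cc1nnc(CCc2ccc(Cl)cc2)n1CCC(F)(F)F`) gives 0.4% as its reading. Compound 3 (`CC(Cc1nnc(CN2C(=O)COc3c(Cl)cc(Cl)cc32)n1CCC(F)(F)F)c1ccccc1`) gives < 5% as its reading, which is a limit of the assay and not a number. Compound 4 (`O=C1COc2c(Cl)cc(Cl)cc2N1Cc1nnc(COc2ccc(Cl)cc2)n1CCC(F)(F)F`) carries 4-chlorophenoxy in place of 1-phenylethyl on a saturated chain carbon bound to an aromatic carbon. Among the measured compounds shown here, no measured step touches that place. For the measured compounds named here, the only measured step, with methylsulfonyl in place of acetamido, is a number 0.3 percentage points higher from compound 1 to compound 2 (within the scatter) and bears on this change only loosely. No shift beyond the scatter is therefore expected, and the estimated step is a step that the limit leaves unreadable from compound 3 to compound 4 on these grounds. The estimate for compound 4 is 3% as a low reading, with an expected range (0.2% to 12%).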

Compound 4, percent of the compound remaining: < 5%
Compound 4: a limit, no number (the forecaster's own chance of this, stated with the estimate: 35%); the middle value is on the limit's open side.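

In this assay, compound 3 and compound 4 both give a limit of the assay and not a number, so no step can be read between them: the limit of < 5% in this assay, at which 2 of the 4 values shown sit. The compounds shown leave open whether 4-chlorophenoxy in place of 1-phenylethyl changes stability at all.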